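The source may hold more compounds than are shown below. What is called first, only, known or untested is meant among the compounds shown, and "the series" means these compounds.

In a functional assay on B16 cells (Mus musculus) for cytotoxicity, read by MTT assay, with a stated time of 48 h (a higher number here means a weaker inhibitor, a lower number a stronger inhibitor), compound 1 `O=C(NCc1cn(Cc2ccccc2)nn1)c1cn(Cc2ccccc2)nn1` gives 300 nM and compound 2 `O=C(Cn1cc(C(=O)NCc2cn(Cc3ccccc3)nn2)nn1)OCc1ccccc1` gives 22400 nM, the higher of these two numbers. Compound 3 `CCOC(=O)Cn1cc(CNC(=O)c2cn(CC(=O)OCc3ccccc3)nn2)nn1` gives > 100000 nM, which is a limit of the assay and not a number. Compound 4 `CC(=O)OCCn1cc(C(=O)NCc2cn(Cc3ccccc3)nn2)nn1`, not yet measured, carries acetoxymethyl in place of benzyloxycarbonyl on a saturated chain carbon bound to an aromatic nitrogen. Among the measured compounds shown here, two measured steps bear on this change, and both put an ester group in place of phenyl and raised the number: the large 75-fold higher number from compound 1 to compound 2 (1.87 log units; beyond the scatter) and the at least modest an at least 4.4-fold higher number from compound 2 to compound 3 (0.64 log units; beyond the scatter). Since this change also removes a phenyl ring, a further rise is expected in this assay, estimated as a 2.0-fold higher number from compound 2 to compound 4 (0.30 log units; within the scatter). Compound 4 is expected at 45000 nM, with an estimated range of 14000 nM to 130000 nM.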

Compound 4, half-maximal inhibitory concentration: > 100000 nM
Compound 4 ended at the assay's limit; the forecaster's own chance of this, stated with the estimate: 30%; middle value at least 2.2-fold (0.34 log units) from the limit.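

In this assay, acetoxymethyl in place of benzyloxycarbonyl gives an at least 4.4-fold higher number from compound 2 to compound 4 (0.64 log units; beyond the scatter), so at this place, with the rest of compound 2 unchanged, an ester group without a phenyl ring gives a weaker inhibitor than benzyloxycarbonyl does. Acetoxymethyl in place of phenyl gives an at least 330-fold higher number from compound 1 to compound 4 (2.52 log units; beyond the scatter), the widest step shown. Compound 4 gives > 100000 nM, a limit of the assay and not a number, so the full size of both steps cannot be told: the limit of > 100000 nM in this assay, at which 2 of the 4 values shown sit.

The compounds shown leave open how a carboxylic acid, an amine or a plain longer alkyl chain on this carbon would compare with phenyl.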